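The compounds below may be only part of what the source reports. "The series", "measured", "known", "first", "only" and "open" are said of these compounds alone.

Working notes on the urea series.

Compound 2 `O=C(NCc1ccccc1)N(Cc1ccccn1)n1cnnc1` carries a benzyl on the amide-type nitrogen. In a functional assay on A549 cells (Homo sapiens) for cytotoxicity, read by MTT assay, with a stated time of 48 h (on this read-out lower numbers stand for stronger inhibition and higher numbers for weaker inhibition), compound 2 gives 22000 nM. For the measured compounds named here, compound 1 `COc1ccc(CN(C(=O)Nc2ccc(C)cc2)n2cnnc2)cc1OC` is the only other measured member of the set; in this assay compound 1 gives 22200 nM, and the two numbers lie within the scatter of each other, so neither can be set apart from the other.

Compound 3 `Cc1ccc(NC(=O)N(Cc2ccccn2)n2cnnc2)cc1` is the next member to be measured. Against compound 2 the change is 4-methylphenyl in place of benzyl on an amide-type nitrogen. Going by the values given here, no measured pair differs in just one place, so no direct step for this exchange is at hand. Compound 1 already carries a 4-methylphenyl on the same nitrogen, and its number sits beside that of compound 2; the step from compound 2 to compound 3 is therefore expected to stay within the scatter, no change at the digits printed from compound 2 to compound 3 (within the scatter). For compound 3 in this assay the estimate is 22000 nM, with a range of 8000 nM to 60000 nM.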

Compound 3, half-maximal inhibitory concentration: 21900 nM
For compound 3 the middle estimate is 1.0-fold (0.00 log units) above the measured one; measured number inside the range.
By their numbers in this assay, from the lowest: compounds 3, 2 and 1 (each within the scatter of the next).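

In this assay, the exchange of benzyl for 4-methylphenyl on the amide-type nitrogen gives a 1.0-fold lower number from compound 2 to compound 3 (0.00 log units; within the scatter). For the compounds shown here, this is the first reading of this change with the rest of the molecule held constant, since compound 1 and compound 2 differ in more than one place and could not isolate it. At this position the two groups cannot be told apart on this read-out, and nothing at hand bears on why they read alike.

Going by these compounds, whether a different kind of group on this nitrogen, such as an amine, a carboxylic acid or a longer alkyl chain, would move the number beyond the scatter remains open. Also open, on these data alone, is whether the same exchange would read alike on the core of compound 1.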